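A Carbamate on the Ring Nitrogen of Compound 1

The source may report more compounds than this note shows. Statements on the series, on what has been measured and on what is new or still open speak of the compounds shown alone.

Of the compounds shown here, three have been tested in a functional assay for antagonist activity at integrin alpha-5/beta-1 (Homo sapiens), read by ELISA; on this read-out lower numbers stand for stronger inhibition and higher numbers for weaker inhibition. Compound 1 `Cc1cc(C)c(S(=O)(=O)N[C@@H](CNC(=O)C2=NO[C@]3(CN[C@H](CNc4ncc[nH]4)C3)C2)C(=O)O)c(C)c1` carries a free ring amine and gives 230 nM. Compound 2 `COC(=O)N1C[C@@]2(CC(C(=O)NC[C@H](NS(=O)(=O)c3c(C)cc(C)cc3C)C(=O)O)=NO2)C[C@H]1CNc1nc2ccccc2[nH]1`, which bears a methoxycarbonyl on the corresponding ring nitrogen together with a different aromatic amine, gives 1.4 nM. Compound 3 `Cc1cc(C)c(S(=O)(=O)[C@@H](CNC(=O)C2=NOC3(CCC(CNc4ncc[nH]4)CC3)C2)C(=O)O)c(C)c1`, built on a different core, gives 1500 nM.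

Among these three numbers, compound 1 stands second highest. Its nearest neighbour is compound 3, whose number is higher by a gap beyond the usual scatter; furthest away is compound 2, whose number is lower by a gap well beyond the scatter.

The step to compound 4 `CCCCOC(=O)N1C[C@@]2(CC(C(=O)NC[C@H](NS(=O)(=O)c3c(C)cc(C)cc3C)C(=O)O)=NO2)C[C@H]1CNc1ncc[nH]1` is butoxycarbonyl in place of hydrogen on an amine nitrogen in a ring. Within the data shown here, no measured pair isolates this single change, so the expectation rests on the overall spread: the only compound carrying a carbamate on this nitrogen, compound 2, gives the lowest number, 1.4 nM. The step from compound 1 to compound 4 is therefore expected to be a clear drop, beyond the scatter, a 12-fold lower number from compound 1 to compound 4 (1.06 log units; beyond the scatter). Compound 4 is estimated at 20 nM, within a range from 4 nM to 100 nM.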

Compound 4, half-maximal inhibitory concentration: 14 nM
Compound 4: middle estimate off by 1.4-fold (0.15 log units), on the high side; the measured number falls inside the stated range.
By their numbers in this assay, from the lowest: compound 2; then compound 4; then compound 1; then compound 3.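

In this assay, butoxycarbonyl in place of hydrogen on the amine nitrogen of the five-membered ring gives a 16-fold lower number from compound 1 to compound 4 (1.22 log units; beyond the scatter), a large step beyond the scatter. Among these compounds, this is the first pair of compounds here that differ in this one place alone, so the drop can be tied to this nitrogen without the change in aromatic amine that separates compound 1 from compound 2: with the ((1H-imidazol-2-yl)amino)methyl group unchanged, the ring nitrogen need not carry a hydrogen for inhibition in this assay to be stronger. No measurement shown here explains why the number falls, so the step records an effect and not its cause.

The compounds shown leave open whether the gain needs the carbamate as such or only something larger on this nitrogen: a plain butyl chain or an acetyl group at the same place, with the rest of compound 4 kept, would help separate the two. They also leave open how far this group can change, for instance to a longer hexyloxycarbonyl chain or to a benzyloxycarbonyl group, which carries a ring.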